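The source may hold more compounds than are shown below. What is called first, only, known or untested is meant among the compounds shown, and "the series" means these compounds.

In a functional assay for antagonist activity at melanin-concentrating hormone receptor 1 (Homo sapiens) (on this read-out higher numbers stand for weaker inhibition and lower numbers for stronger inhibition), compound 1 `CC(C)N(CCN(C(=O)Nc1cccc([N+](=O)[O-])c1)C1CC[C@]2(c3cccc(C#N)c3)CC2C1)C(C)C` gives 2.7 nM, and compound 2 `CC(C)N(CCN(C(=O)Nc1ccc(F)c(F)c1)C1CC[C@]2(c3cccc(Br)c3)CC2C1)C(C)C` gives 7.76 nM. Compound 3 `CCO/N=C/c1cccc([C@]23CCC(N(CCN(C(C)C)C(C)C)C(=O)Nc4ccc(F)c(Cl)c4)CC2C3)c1` gives 29 nM in this assay, the highest of the three numbers; the gap to compound 2 is the smaller of its two, and the gap to compound 1 the larger, both being beyond the usual scatter.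

Compound 4 `CCN(CC)Cc1cccc([C@]23CCC(N(CCN(C(C)C)C(C)C)C(=O)Nc4ccc(F)c(Cl)c4)CC2C3)c1` differs from compound 3 in one place: a group of 6 heavy atoms (5 carbon, 1 nitrogen; no ring) in place of a group of 5 heavy atoms (3 carbon, 1 nitrogen, 1 oxygen; no ring), on an aromatic carbon. For the measured compounds named here, no measured pair tracks this particular exchange, so the expectation rests on the closeness of the two groups in size. The step from compound 3 to compound 4 is expected to be small, a 1.5-fold lower number from compound 3 to compound 4 (0.16 log units; within the scatter), not clearly beyond the scatter. Compound 4 is therefore estimated at 20 nM in this assay, with a plausible range from 5 nM to 80 nM.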

Compound 4, inhibition constant: 46 nM
The estimate for compound 4 lay 2.3-fold (0.36 log units) below the measured number; the range from low to high includes it.
By their numbers in this assay, from the lowest: compound 1; then compound 2; then compounds 3 and 4 (each within the scatter of the next).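

In this assay, putting (diethylamino)methyl in place of the open-chain group of compound 3 gives a 1.6-fold higher number from compound 3 to compound 4 (0.20 log units; within the scatter) on this aromatic carbon. For this pair, the oxygen and the double bond of the departing group are therefore not needed to keep the number at this level, and a chain carrying only a nitrogen serves as well. Nothing measured here bears on why the two groups read alike. Going by these compounds, what remains open is how a carboxylic acid, a primary amine or a longer chain would read on this carbon.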